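A Phenolic Aryl Group in Place of the Chlorobenzyl Arm

This account rests on a few compounds, and the source may have more. Where it says the series, first, only, none or still open, it means among the compounds named here.

Compound 1 `OC[C@H]1O[C@@H](n2cnc3c(NCc4ccc(Cl)cc4)ncnc32)[C@H](O)[C@@H]1O` gives the lowest number of the three measured compounds in a functional assay on HL-60 cells (Homo sapiens) for antiproliferative activity, with a stated time of 72 h (a higher number here means a weaker inhibitor, a lower number a stronger inhibitor), at 1700 nM. Compound 2 `OC[C@H]1O[C@@H](n2cnc3c(NCc4ccc(Cl)c(Cl)c4)ncnc32)[C@H](O)[C@@H]1O` gives 2000 nM, and compound 3 `OC[C@H]1O[C@@H](n2cnc3c(NCc4ccc(F)c(F)c4F)ncnc32)[C@H](O)[C@@H]1O` gives 13000 nM. The step of a 1.2-fold higher number from compound 1 to compound 2 (0.07 log units; within the scatter) lies within the scatter, whereas a 7.6-fold higher number from compound 1 to compound 3 (0.88 log units; beyond the scatter) and a 6.5-fold higher number from compound 2 to compound 3 (0.81 log units; beyond the scatter) lie beyond it. Compound 4 `Cc1ccc(O)c(CNc2ncnc3c2ncn3[C@@H]2O[C@H](CO)[C@@H](O)[C@H]2O)c1` differs from compound 1 by 2-hydroxy-5-methylphenyl in place of 4-chlorophenyl on a saturated chain carbon bound to a nitrogen on an aromatic ring. For the measured compounds named here, no measured step exchanges a chlorine for a hydroxyl or a methyl group; the two steps to compound 3 show only that a different substitution of the ring can raise the number modestly. Compound 4 is therefore expected to give a somewhat higher number, a 2.4-fold higher number from compound 1 to compound 4 (0.37 log units; beyond the scatter), with an estimate of 4000 nM between 1200 nM and 15000 nM.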

Compound 4, half-maximal inhibitory concentration: 15000 nM
The estimate for compound 4 lay 3.8-fold (0.57 log units) below the measured number; low and high end bracket the measured number.
By their numbers in this assay, from the lowest: compounds 1 and 2 (each within the scatter of the next); then compounds 3 and 4 (each within the scatter of the next).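

The change to 2-hydroxy-5-methylphenyl gives a modest rise at this position, seen both in the step (an 8.8-fold higher number from compound 1 to compound 4 (0.95 log units; beyond the scatter)) and in the step (a 7.5-fold higher number from compound 2 to compound 4 (0.88 log units; beyond the scatter)). A ring with a hydroxyl and a methyl group reads level with the fluorinated ring (a 1.2-fold higher number from compound 3 to compound 4 (0.06 log units; within the scatter)), and among these four compounds only the chlorinated rings, in compounds 1 and 2, give the lower numbers. Nothing measured here accounts for that shift. Going by these compounds, the hydroxyl and the methyl group enter together, and their separate shares stay open. On these data alone, how a methoxy group or an amine on this ring would read also remains unknown.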